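Thioether aryl variations on the shared nucleoside core

The source may report more compounds than this note shows. Statements on the series, on what has been measured and on what is new or still open speak of the compounds shown alone.

Compound 3 `Cc1cccc(CSc2ncnc3c2ncn3[C@@H]2O[C@H](CO)[C@@H](O)[C@H]2O)c1` gives 12000 nM in an assay on isolated protein for binding affinity to Equilibrative nucleoside transporter 1 (Homo sapiens) (on this read-out higher numbers stand for weaker inhibition and lower numbers for stronger inhibition), the second highest of the three numbers recorded. Compound 1 `CC(C)(Sc1ncnc2c1ncn2[C@@H]1O[C@H](CO)[C@@H](O)[C@H]1O)c1ccccc1` gives 21400 nM and compound 2 `CC(C)c1ccc(CSc2ncnc3c2ncn3[C@@H]2O[C@H](CO)[C@@H](O)[C@H]2O)cc1` gives 4790 nM. The step of a 1.8-fold lower number from compound 1 to compound 3 (0.25 log units; within the scatter) and the step of a 2.5-fold higher number from compound 2 to compound 3 (0.40 log units; beyond the scatter) both alter the part attached to the sulfur; only the second moves beyond the scatter, and only modestly. Compound 4 `OC[C@H]1O[C@@H](n2cnc3c(CSc4cccc(I)c4)ncnc32)[C@H](O)[C@@H]1O` differs from compound 3 by a group of 9 heavy atoms (7 carbon, 1 sulfur, 1 iodine; one six-membered aromatic ring of carbon only) in place of a group of 9 heavy atoms (8 carbon, 1 sulfur; one six-membered aromatic ring of carbon only), on an aromatic carbon. Both earlier steps bear on this change, since each swaps one aryl-bearing group for another on the sulfur side, and neither moved the number far. The expected step is therefore a 1.2-fold lower number from compound 3 to compound 4 (0.08 log units; within the scatter), in no clear direction. Compound 4 is estimated at 10000 nM, with a range of 3500 nM to 30000 nM.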

Compound 4, half-maximal inhibitory concentration: 245 nM
Compound 4: the middle estimate sits 41-fold (1.61 log units) above what was measured; measured number below the stated range.
By their numbers in this assay, from the lowest: compound 4; then compound 2; then compounds 3 and 1 (each within the scatter of the next).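

Swapping the group on this aromatic carbon can move the number far: a 49-fold lower number from compound 3 to compound 4 (1.69 log units; beyond the scatter), a large step, where the earlier steps were within the scatter or modest. Two features change together here: iodine stands in place of methyl, and a saturated carbon rather than sulfur now joins the group to the shared core, with sulfur bound to the aromatic ring. No supporting data on the cause of this step are available.

Which of the two features carries the step remains open. Also open, as far as these compounds go, is how bromine or an amine in place of the iodine would read.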